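Methyl in Place of Chloro on Two Different Cores

A few compounds are considered here, and "the series" means these few. Any claim that something is new, unique, unknown or untested is made for them only; others in the source may bear on it.

Compound 1 `C=C(Br)C(=O)Nc1cccc(/C=C2\SC(=O)N(Cc3ccc(C)cc3)C2=O)c1` gives 1000 nM
Compound 2 `C=C(Br)C(=O)Nc1cccc(/C=C2\SC(=O)N(Cc3ccc(Cl)cc3)C2=O)c1` gives 1600 nM
Compound 3 `Nc1ccc(/C=C2\SC(=O)N(Cc3ccc(Cl)cc3)C2=O)cc1` gives 60000 nM

All three were tested in a functional assay on FM3A cells (Mus musculus) for cytotoxicity, read by cell counting, with a stated time of 2 days; on this read-out higher numbers stand for weaker inhibition and lower numbers for stronger inhibition. Compound 2 and compound 1 share one core and differ in a single place, (methyl in place of chloro on an aromatic carbon); in this assay that change gave a 1.6-fold lower number from compound 2 to compound 1 (0.20 log units; within the scatter). Compound 3 rests on another core, and the difference between the two cores is not broken down here. In this assay compound 3 stands with the highest number of the three, beyond the scatter from both others.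

Compound 4 `Cc1ccc(CN2C(=O)S/C(=C\c3ccc(N)cc3)C2=O)cc1` has not yet been measured. It differs from compound 3 by methyl in place of chloro on an aromatic carbon, the same change, at the same place, as that from compound 2 to compound 1. Because the earlier step was a 1.6-fold lower number from compound 2 to compound 1 (0.20 log units; within the scatter), a step of similar small size is expected this time, a 1.3-fold lower number from compound 3 to compound 4 (0.12 log units; within the scatter). Compound 4 is therefore expected to give about 45000 nM in this assay, most likely between 18000 nM and 110000 nM, which would keep it far from compound 1 and compound 2.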

Compound 4, half-maximal inhibitory concentration: > 250000 nM
Compound 4: no number, only a limit (the forecaster's own chance of this, stated with the estimate: 10%); at least 5.5-fold (0.74 log units) between middle value and limit.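

On the core of compound 3, methyl in place of chloro gave an at least 4.1-fold higher number from compound 3 to compound 4 (0.61 log units; beyond the scatter) in this assay, so a change that made no step beyond the scatter on one core made a clear one on the other. The change therefore does not carry over at the same size from the core of compound 1 to the core of compound 3, and the series offers one pair on each core to show this: the same change on two cores in this assay, a 1.6-fold lower number (0.20 log units; within the scatter) from compound 2 to compound 1 and an at least 4.1-fold higher number (0.61 log units; beyond the scatter) from compound 3 to compound 4, at least 6.6-fold (0.82 log units) apart, beyond the scatter of two such steps. What this does not show is how large the step on the core of compound 3 really is, or why the two cores part, since compound 4 gives only a limit of the assay and not a number: the limit of > 250000 nM in this assay, at which 1 of the 4 values shown sits.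

The compounds shown leave open how a fluoro, a methoxy or a carboxylic acid in the same place would behave on either core. They also leave open which of the two steps, if either, the same change would follow on a third core.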